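Swapping a Methylcyclohexyl for a Difluorophenyl on the Amide Nitrogen

This account rests on a few compounds, and the source may have more. Where it says the series, first, only, none or still open, it means among the compounds named here.

Compound 1 `CC1CCCCC1N(CCCCCCN1C[C@H](O)[C@@H](O)[C@H](O)[C@H]1CO)C(=O)OC(C)(C)C` in an ADME assay on BHK cells (Mesocricetus auratus) for cytotoxicity, read by MTT assay; on this read-out higher numbers stand for lower toxicity in this test and lower numbers for higher toxicity in this test: 230000 nM.
Compound 2 `CC1CCCCC1N(CCCCCCN1C[C@H](O)[C@@H](O)[C@H](O)[C@H]1CO)C(=O)C(C)(C)C`: > 500000 nM, a limit.
Compound 3 `CC(C)(C)CC(=O)N(CCCCCCN1C[C@H](O)[C@@H](O)[C@H](O)[C@H]1CO)C1CCCCC1`: > 500000 nM, a limit.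

Compound 2 stands at the limit, as the limit of > 500000 nM in this assay, at which 2 of the 3 values shown sit, shows, and only a limit is known for it. Compound 3 likewise gives only a limit. Among the measured compounds shown here, the one measured step, an at least 2.1-fold higher number from compound 1 to compound 2 (0.33 log units; beyond the scatter), reaches that limit but leaves the group on the amide-type nitrogen untouched. Compound 4 `CC(C)(C)C(=O)N(CCCCCCN1C[C@H](O)[C@@H](O)[C@H](O)[C@H]1CO)c1ccc(F)cc1F` carries 2,4-difluorophenyl in place of 2-methylcyclohexyl on an amide-type nitrogen. For the measured compounds named here, no measured step bears on this change, so there is no basis for expecting a move beyond the scatter in this assay. Compound 4 is therefore expected to give about 500000 nM, between 200000 nM and 1200000 nM, which amounts to an expected a number no higher from compound 2 to compound 4 (the limit leaves the size open).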

Compound 4, half-maximal cytotoxic concentration: > 500000 nM
Compound 4: only a limit was reported (the forecaster's own chance of this, stated with the estimate: 60%); the middle value sits exactly at the limit.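

Compound 2 and compound 4 both give only a limit, so no step between them can be read: the limit of > 500000 nM in this assay, at which 3 of the 4 values shown sit.

The compounds shown leave open whether 2,4-difluorophenyl in place of 2-methylcyclohexyl on the amide-type nitrogen changes the number at all.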